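The source may report more compounds than this note shows. Statements on the series, on what has been measured and on what is new or still open speak of the compounds shown alone.

Measured so far:
compound 1, `Cc1ccccc1CN1CC=C(CCC(=O)NO)C1=O`, giving 3330 nM
compound 2, `O=C(CCC1=CCN(Cc2ccc(F)cc2)C1=O)NO`, giving 5990 nM
compound 3, `Cc1ccc(CCCCN2CC=C(CCC(=O)NO)C2=O)cc1`, giving 3730 nM

All three numbers come from a functional assay on ACHN cells (Homo sapiens) for inhibition, read by sulforhodamine B assay; a lower number here means a stronger inhibitor of growth, a higher number a weaker inhibitor of growth. Compound 3 stands in the middle of a tight group: its value lies within the usual scatter of compound 1 and also within the scatter of compound 2, so on these numbers none of the three can be set apart from the others, and the shared core carrying the hydroxamic acid chain appears to tolerate the different benzylic and butyl-linked aryl groups without a clear effect.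

Compound 4, `O=C(CCC1=CCN(CCCCc2ccc(Cl)cc2)C1=O)NO`, has not yet been measured. It differs from compound 3 in one place: chloro in place of methyl on an aromatic carbon. Going by the values given here, no pair of measured compounds shows how this exchange moves the number, so the expectation rests only on the closeness of the three measured values. The expected step, a 1.1-fold lower number from compound 3 to compound 4 (0.03 log units; within the scatter), is one of no change beyond the scatter. Compound 4 is therefore estimated at 3500 nM, with a range from 1500 nM to 8000 nM.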

Compound 4, concentration for 50% growth inhibition: 3730 nM
Beside the measured number, compound 4's estimate is 1.1-fold (0.03 log units) below it, within the range that was stated.
By their numbers in this assay, from the lowest: compounds 1, 3, 4 and 2 (each within the scatter of the next).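

Chloro in place of methyl on the aromatic carbon para to a large group, that is 4-methylphenyl to 4-chlorophenyl, gives in this assay a step of no change at the digits printed from compound 3 to compound 4 (within the scatter). This is the first pair shown that differs in one place only, so the earlier compounds could suggest only a general closeness of values, whereas this pair shows directly that this position accepts the exchange without a shift beyond the scatter. Nothing available bears on why the two groups read alike.

As far as these compounds go, whether an amine, a carboxylic acid or a nitrile at this position would move the number remains open. Also open, from the compounds shown here alone, are the effect of a longer chain to the aromatic ring and whether the same exchange would read alike on a benzyl group such as that of compound 1.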